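The compounds below may be only part of what the source reports. "The series", "measured", "known", "first", "only" and "open" are said of these compounds alone.

Working notes on the series. Compound 1 `Cc1ccnc2nc(-c3cccc(Cl)c3)cc(O)c12` gives 38.9 nM in a functional assay on NCI-H460 cells (Homo sapiens) for antiproliferative activity; on this read-out higher numbers stand for weaker inhibition of growth and lower numbers for stronger inhibition of growth. Compound 3 `Cc1cc(C)c2c(O)cc(-c3cccc(Cl)c3)nc2n1` gives 224 nM in this assay; the change is methyl in place of hydrogen on an aromatic carbon, and the step is a 5.8-fold higher number from compound 1 to compound 3 (0.76 log units; beyond the scatter). Compound 2 `Oc1cc(-c2ccc3ccccc3c2)nc2ncccc12` gives 3800 nM in this assay, the highest number of the three measured compounds. The difference between the core of compound 2 and the core of compound 1 is not broken down here.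

Compound 4 `Cc1ccc2c(O)cc(-c3ccc4ccccc4c3)nc2n1` is not yet measured in this assay. It differs from compound 2 by methyl in place of hydrogen on an aromatic carbon. This is the same kind of change as that from compound 1 to compound 3, though the surroundings differ: in the earlier pair the place is also meta to a methyl group, which is absent in compound 2. On the basis of that single earlier step, a rise in number is expected from compound 2 to compound 4, of about a 2.9-fold higher number from compound 2 to compound 4 (0.46 log units; beyond the scatter), taken somewhat smaller than the earlier one because it rests on one observation only (a 5.8-fold higher number from compound 1 to compound 3 (0.76 log units; beyond the scatter)). Compound 4 is therefore estimated at 11000 nM, between 4000 nM and 40000 nM.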

Compound 4, concentration for 50% growth inhibition: 3800 nM
For compound 4 the middle estimate is 2.9-fold (0.46 log units) above the measured one; measured number outside the range, below it.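

In this assay the new step reads no change at the digits printed from compound 2 to compound 4 (within the scatter), so methyl in place of hydrogen on an aromatic carbon leaves the number unmoved on this core, unlike the step seen on the other core. The change therefore does not carry over at a fixed size between these two cores: the same change on two cores in this assay, a 5.8-fold higher number (0.76 log units; beyond the scatter) from compound 1 to compound 3 and no change at the digits printed (within the scatter) from compound 2 to compound 4, 5.8-fold (0.76 log units) apart, beyond the scatter of two such steps. The two pairs differ from each other in more than one place, so the data do not show which of those differences sets the gap, and one pair on each core gives no rule for any further core.

The compounds shown leave open whether an amine or a longer chain in place of that methyl would move the number on either core. Also open, on these data alone, is whether the same methyl change on a third core would raise the number, as it does from compound 1 to compound 3, or leave it unmoved, as it does from compound 2 to compound 4.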